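This account rests on a few compounds, and the source may have more. Where it says the series, first, only, none or still open, it means among the compounds named here.

Three urea compounds built on a shared core have been measured in an assay on microsomes from intestine for inhibition of acyl-CoA:cholesterol acyltransferase (Oryctolagus cuniculus); a higher number here means a weaker inhibitor, a lower number a stronger inhibitor. Compound 1, with structure `Cc1cc(C)c(NC(=O)N(Cc2ccc(-c3cn[nH]c3)cc2)C2CCCCCC2)c(C)c1`, gives 270 nM. Compound 3, with structure `Cc1cc(C)c(NC(=O)N(Cc2ccc(-c3ccn(C)n3)cc2)C2CCCCCC2)c(C)c1`, gives 44 nM. The step from compound 1 to compound 3 is a 6.1-fold lower number from compound 1 to compound 3 (0.79 log units; beyond the scatter), and the change that produces it is 1-methyl-1H-pyrazol-3-yl in place of 1H-pyrazol-4-yl on an aromatic carbon. Compound 2, with structure `Cc1cc(C)c(NC(=O)N(Cc2cccc(-c3cn[nH]c3)c2)C2CCCCCC2)c(C)c1`, gives 38 nM. Compound 2 and compound 1 are built from the same atoms joined differently, and the difference between the two cores is not broken down here; the values of compound 2 and compound 3 sit within the usual scatter of each other, so no order can be read between them.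

Compound 4, with structure `Cc1cc(C)c(NC(=O)N(Cc2cccc(-c3ccn(C)n3)c2)C2CCCCCC2)c(C)c1`, is not yet measured. It is obtained from compound 2 by 1-methyl-1H-pyrazol-3-yl in place of 1H-pyrazol-4-yl on an aromatic carbon. Going by the values given here, this is the same kind of change as the one from compound 1 to compound 3, but the place differs: in compound 1 the group sits para to a large group, whereas in compound 2 it sits meta to a large group. Carrying the earlier step over, compound 4 is expected to be stronger than compound 2 by about a 3.8-fold lower number from compound 2 to compound 4 (0.58 log units; beyond the scatter), a somewhat smaller step than the measured one, because compound 2 already gives 38 nM and the surroundings of the change are not identical. The estimated value for compound 4 in this assay is therefore 10 nM, with a likely range from 3 nM to 40 nM.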

Compound 4, half-maximal inhibitory concentration: 42 nM
Compound 4: the middle estimate sits 4.2-fold (0.62 log units) below what was measured, and the stated range ends below it.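

Putting 1-methyl-1H-pyrazol-3-yl in place of 1H-pyrazol-4-yl gives a 1.1-fold higher number from compound 2 to compound 4 (0.04 log units; within the scatter) in this assay, so no difference in strength can be read for this pair. Going by these compounds alone, the same change therefore does not give the same result on the two cores, and the gap between the two steps is larger than chance scatter would readily explain: the same change on two cores in this assay, a 6.1-fold lower number (0.79 log units; beyond the scatter) from compound 1 to compound 3 and a 1.1-fold higher number (0.04 log units; within the scatter) from compound 2 to compound 4, 6.8-fold (0.83 log units) apart, beyond the scatter of two such steps This shows that the gain seen on the core of compound 1 does not carry over to the core of compound 2, so a step measured on one core is a poor guide to the other, but with only two pairs it does not show why the cores differ or what the change would do on any further core.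

The swap alters two things at once, adding a methyl group and changing the ring carbon through which the pyrazole is attached, so the compounds shown leave open which of the two drives the step on the core of compound 1. Testing 1-methyl-1H-pyrazol-4-yl on each core would separate these two effects, while a pyridine ring or a carboxylic acid in the same place remains an open question.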